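A Fluoro Step on a Weakly Cytotoxic Compound

The source may hold more compounds than are shown below. What is called first, only, known or untested is meant among the compounds shown, and "the series" means these compounds.

Values from a functional assay on MDA-MB-231 cells (Homo sapiens) for cytotoxicity, with a stated time of 48 h (a lower number here means a stronger inhibitor, a higher number a weaker inhibitor), are as follows.
- compound 1 `COc1cc(O)c(C(=O)/C=C/c2ccc(F)cc2)c(OC)c1` gives > 20000 nM (a limit)
- compound 2 `COc1cc(OC)c(C(=O)/C=C/c2ccccc2)c(OC)c1` gives 12900 nM (a measured number)

Going by the values given here, compound 2 holds the only actual number in this small set, at 12900 nM in this assay and so serves as the sole numerical reference. The result for compound 1 is > 20000 nM and is a limit.

Compound 3 `COc1cc(OC)c(C(=O)/C=C/c2ccc(F)cc2)c(OC)c1` arises from compound 2 through one change fluoro in place of hydrogen on an aromatic carbon with fluoro in place of hydrogen on an aromatic carbon, para to a large group. Among the compounds with values here, no measured pair differs in one place only, so this assay offers no direct precedent for this step. A small step with no firm direction is expected. The estimated 1.1-fold lower number from compound 2 to compound 3 (0.03 log units; within the scatter) is expected to lie within the usual scatter of repeated measurements. The estimate for compound 3 is 12000 nM and the expected range runs from 6000 nM to 20000 nM in the measurement still to come.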

Compound 3, half-maximal inhibitory concentration: 10700 nM
Compound 3: the middle estimate sits 1.1-fold (0.05 log units) above what was measured; the range from low to high includes it.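

In this assay, going by these compounds alone, fluoro in place of hydrogen on an aromatic carbon, para to a large group, gives the first one-place comparison at this position, and a 1.2-fold lower number from compound 2 to compound 3 (0.08 log units; within the scatter), so the two compounds cannot be told apart here. The same result opens a second one-place comparison, at the oxygen on the aromatic ring, where methyl stands in place of hydrogen: an at least 1.8-fold lower number from compound 1 to compound 3 (0.27 log units; that floor lies within the scatter). Compound 1 gives only a limit, so this step is a floor and does not settle whether that methyl matters: the limit of > 20000 nM in this assay, at which 1 of the 3 values shown sits.

Going by these compounds, it remains open whether another group at the para position, such as chloro, an amine or a carboxylic acid, would move the number beyond the scatter. Also open, on these data alone, is what a longer chain in place of methyl on that oxygen would give.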